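A few compounds are considered here, and "the series" means these few. Any claim that something is new, unique, unknown or untested is made for them only; others in the source may bear on it.

Measured in a functional assay on HEK-293T cells (Homo sapiens) for cytotoxicity, read by MTT assay; on this read-out lower numbers stand for higher toxicity in this test and higher numbers for lower toxicity in this test:
- compound 1 `COc1ccc(-c2nc3cnccn3c2Nc2cc(OC)c(OC)c(OC)c2)cc1`: 54000 nM
- compound 2 `COc1cc(Nc2c(-c3cccc(O)c3)nc3cnccn23)cc(OC)c1OC`: 42000 nM
- compound 3 `COc1cc(-c2nc3cnccn3c2Nc2cc(OC)c(OC)c(OC)c2)cc(OC)c1O`: 34000 nM

Compound 3, at 34000 nM, cannot be told apart from the other two, since all three values lie within the usual scatter. Compound 4 `COc1cc(Nc2c(C3C=Nc4ccccc43)nc3cnccn23)cc(OC)c1OC` loses the 4-hydroxy-3,5-dimethoxyphenyl group of compound 3, on an aromatic carbon: a group of 9 heavy atoms (8 carbon, 1 nitrogen; one five-membered non-aromatic ring with 1 hetero atom, one six-membered aromatic ring of carbon only) in place of a group of 11 heavy atoms (8 carbon, 3 oxygen; one six-membered aromatic ring of carbon only), on an aromatic carbon. Earlier swaps at this same carbon stayed small: a 1.3-fold lower number from compound 1 to compound 2 (0.11 log units; within the scatter), a 1.6-fold lower number from compound 1 to compound 3 (0.20 log units; within the scatter) and a 1.2-fold lower number from compound 2 to compound 3 (0.09 log units; within the scatter). None of those groups contains a non-aromatic ring, so this guide is loose. Even so, no change beyond the scatter is expected. The expected step is a 1.2-fold higher number from compound 3 to compound 4 (0.09 log units; within the scatter). For compound 4 the estimated value is 42000 nM, with an expected range of 17000 nM to 100000 nM.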

Compound 4, concentration lethal to 50% of the cells: 12000 nM
The estimate for compound 4 lay 3.5-fold (0.54 log units) above the measured number, outside the stated range (below it).
By their numbers in this assay, from the lowest: compound 4; then compounds 3, 2 and 1 (each within the scatter of the next).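

Swaps among the substituted phenyl groups of compound 1, compound 2 and compound 3 stayed within the scatter, but the group with the five-membered non-aromatic ring moves the number beyond it in this assay with a 2.8-fold lower number from compound 3 to compound 4 (0.45 log units; beyond the scatter) and a 3.5-fold lower number from compound 2 to compound 4 (0.54 log units; beyond the scatter) and a 4.5-fold lower number from compound 1 to compound 4 (0.65 log units; beyond the scatter) as the steps. This aromatic carbon therefore does respond to its group, with a lower number meaning higher toxicity in this test. No measurement shown here accounts for the shift.

Compound 4 changes the ring, its nitrogen and its double bond together, and these cannot be separated. Going by these compounds, how a morpholine or a carboxylic acid at this carbon would read stays open.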